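Aminopyrimidine imines without measurable effect on HT-29 cells

The compounds below may be only part of what the source reports. "The series", "measured", "known", "first", "only" and "open" are said of these compounds alone.

Compound 1 `CC(C)Nc1nc(Nc2ccc(N3CCN(C)CC3)cc2)ncc1/N=C/c1cccs1`, compound 2 `CC(C)Nc1nc(Nc2ccc(N3CCN(C)CC3)cc2)ncc1/N=C/c1ccc(C(F)(F)F)cc1` and compound 3 `CC(C)Nc1nc(Nc2ccc(S(N)(=O)=O)cc2)ncc1/N=C/c1cccs1` share one core and were tested in a functional assay on HT-29 cells (Homo sapiens) for antiproliferative activity, read by MTT assay; on this read-out lower numbers stand for stronger inhibition and higher numbers for weaker inhibition. Compound 1 only reaches the limit of > 100000 nM. Compound 2 likewise gives only the limit > 100000 nM. Compound 3 also stops at the limit > 100000 nM. The change 4-(trifluoromethyl)phenyl in place of thiophen-2-yl on a carbon with a double bond to nitrogen yields a step that the two limits leave unreadable from compound 1 to compound 2, and the cores differ by sulfamoyl in place of 4-methylpiperazin-1-yl on an aromatic carbon, yielding a step that the two limits leave unreadable from compound 1 to compound 3; neither step can be read because of the limit of > 100000 nM in this assay, at which 3 of the 3 values shown sit.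

Compound 4 `CC(C)Nc1nc(Nc2ccc(S(N)(=O)=O)cc2)ncc1/N=C/c1ccc(C(F)(F)F)cc1` is not yet measured. It carries the same change as the pair before, (4-(trifluoromethyl)phenyl in place of thiophen-2-yl on a carbon with a double bond to nitrogen), at a place described in the same words. Since compound 3 rests at the limit > 100000 nM and the same change showed a step that the two limits leave unreadable from compound 1 to compound 2, the step of a number no higher from compound 3 to compound 4 (the limit leaves the size open) is expected to be unreadable as well. Compound 4 is therefore estimated at 100000 nM, between 30000 nM and 300000 nM, most likely again as a limit.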

Compound 4, half-maximal inhibitory concentration: > 100000 nM
Compound 4 ended at the assay's limit; the forecaster's own chance of this, stated with the estimate: 85%; the middle value sits exactly at the limit.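

In this assay, no step from compound 3 or compound 2 to compound 4 can be read because all values are limits: the limit of > 100000 nM in this assay, at which 4 of the 4 values shown sit.

The compounds shown leave open how thiophen-2-yl and 4-(trifluoromethyl)phenyl, or sulfamoyl and 4-methylpiperazin-1-yl, truly compare on the shared core.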